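Naphthyl replaces phenoxy on the ether chain of compound 3

The source may report more compounds than this note shows. Statements on the series, on what has been measured and on what is new or still open speak of the compounds shown alone.

Three acrylic acids share a core carrying an ether-linked side chain and a benzylic azole. In an assay on CHO cells for displacement of a labelled ligand from prostaglandin E2 receptor EP3 subtype (Mus musculus), read by scintillation counting (a higher number here means a weaker inhibitor, a lower number a stronger inhibitor), compound 1 `O=C(O)/C=C/c1ccc(Cn2cccn2)cc1OCCc1ccc2ccccc2c1` gives 12 nM, compound 2 `Cc1ccc(/C=C/C(=O)O)c(OCCC2(C)CCc3c(C)c(O)c(C)c(C)c3O2)c1` gives 940 nM, and compound 3 `O=C(O)/C=C/c1ccc(Cn2ccnc2)cc1OCCCOc1ccccc1` gives 280 nM. Within this set compound 3 holds the second highest inhibition constant: compound 2 sits above it by a margin beyond the usual scatter, and compound 1 sits well below it, also beyond the scatter, so compound 3 falls between the two, nearer compound 2. No pair among these three differs in a single place, so no measured step is available.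

Compound 4 `O=C(O)/C=C/c1ccc(Cn2ccnc2)cc1OCCc1ccc2ccccc2c1` is the next entry. It differs from compound 3 by naphthalen-2-yl in place of phenoxymethyl on a saturated chain carbon, two bonds along the chain from an oxygen on an aromatic ring. The same naphthylethyl ether is carried by compound 1, which gives the lowest number of the three in this assay, while compound 3 with the phenoxypropyl ether sits far higher. On that basis the step is expected to point downward by a clear margin, estimated as a 9.3-fold lower number from compound 3 to compound 4 (0.97 log units; beyond the scatter). For compound 4 an inhibition constant of about 30 nM is expected, with a likely range from 8 nM to 120 nM.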

Compound 4, inhibition constant: 16 nM
Estimate against measurement, compound 4: 1.9-fold (0.27 log units) above, within the range that was stated.
By their numbers in this assay, from the lowest: compounds 1 and 4 (each within the scatter of the next); then compound 3; then compound 2.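

In this assay, naphthalen-2-yl in place of phenoxymethyl on a saturated chain carbon, two bonds along the chain from an oxygen on an aromatic ring, gives an 18-fold lower number from compound 3 to compound 4 (1.24 log units; beyond the scatter), a large step beyond the scatter and the first single-place reading at this position in the compounds shown. With the naphthalen-2-yl group in place, 1H-imidazol-1-yl in place of 1H-pyrazol-1-yl on a saturated chain carbon bound to an aromatic carbon gives a 1.3-fold higher number from compound 1 to compound 4 (0.12 log units; within the scatter), within the scatter, so this assay does not separate these two azoles on this side chain. Nothing measured here accounts for the size of the step at the ether chain.

The step adds a second aromatic ring and removes the chain oxygen at once, and the compounds shown do not separate these two changes. Open questions are how a plain phenyl or a naphthalen-1-yl group on the same chain carbon would read, and whether a 1H-1,2,4-triazol-1-yl group at the azole position would also stay within the scatter.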